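From 1-carboxyethyl to 1-carboxypropyl on compound 1

A few compounds are considered here, and "the series" means these few. Any claim that something is new, unique, unknown or untested is made for them only; others in the source may bear on it.

In an ADME assay on cells (Hepatocyte, Mus musculus) for metabolic stability, read by LC-MS, with a stated time of 180 min, tested at 1 uM (a higher number here means faster removal of the compound, a lower number slower removal), compound 1 (`CC(C(=O)O)c1nn(Cc2cn3cc(OCC4CC4)c(Cl)cc3n2)c2ccccc2c1=O`) gives 76.7 mL/min/kg and compound 3 (`CC(C(=O)O)c1nn(Cc2cn3cc(OCC4CC4)c(C(F)(F)F)cc3n2)c2ccccc2c1=O`) gives 71.7 mL/min/kg. Among the measured compounds shown here, these are the only two exact numbers, and they lie within the scatter of each other. Compound 2 (`O=C(O)Cn1nc(Cn2cc3cc(OCC4CC4)c(Cl)cc3n2)c2ccccc2c1=O`) gives < 40 mL/min/kg, which is a limit of the assay.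

Compound 4 (`CCC(C(=O)O)c1nn(Cc2cn3cc(OCC4CC4)c(Cl)cc3n2)c2ccccc2c1=O`) differs from compound 1 by methyl in place of hydrogen on a saturated chain carbon, two bonds along the chain from an aromatic carbon and a carbonyl carbon. The same difference reads 1-carboxyethyl to 1-carboxypropyl.

For the measured compounds named here, the only measured step is trifluoromethyl in place of chloro on an aromatic carbon, a 1.1-fold lower number from compound 1 to compound 3 (0.03 log units; within the scatter). Going by the values given here, it lies elsewhere in the structure, and no measured step touches this chain carbon. Among the compounds with values here, with a 1.1-fold lower number from compound 1 to compound 3 (0.03 log units; within the scatter) as the only guide, no step beyond the scatter is expected in this assay, and neither direction is favoured. The estimated step is a 1.1-fold lower number from compound 1 to compound 4 (0.04 log units; within the scatter). The estimate for compound 4 is 70 mL/min/kg, with an expected range of 42 mL/min/kg to 115 mL/min/kg.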

Compound 4, clearance: 155 mL/min/kg
The estimate for compound 4 lay 2.2-fold (0.35 log units) below the measured number, and the stated range ends below it.
By their numbers in this assay, from the lowest: compounds 3 and 1 (each within the scatter of the next); then compound 4. At a limit, below all of these: compound 2.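

In this assay, among the compounds shown here, the saturated chain carbon carrying the carboxylic acid is the first place where a single change moves the number beyond the scatter: going from 1-carboxyethyl to 1-carboxypropyl gives a 2.0-fold higher number from compound 1 to compound 4 (0.31 log units; beyond the scatter). The only earlier step, a 1.1-fold lower number from compound 1 to compound 3 (0.03 log units; within the scatter), was on an aromatic carbon and stayed within the scatter, so of the two places changed, only this chain carbon has shown a response, a modest one resting on a single pair. Nothing measured here bears on why the number rises with this one added methyl.

As far as these compounds go, whether a longer chain such as 1-carboxybutyl, or a second methyl on the same chain carbon, would raise the number further remains open. Also open, from the compounds shown here alone, is whether trifluoromethyl in place of chloro stays within the scatter when 1-carboxypropyl is present.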